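The compounds below may be only part of what the source reports. "The series", "measured", "known", "first", "only" and "open" are said of these compounds alone.

Measured compounds:
compound 1, `CC(C)(C)N(NC(=O)c1ccccc1)C(=O)c1ccccc1Br`, 170 nM in an assay on cells for agonist activity at ecdysone receptor (Bombyx mori), read by a luciferase reporter, with a stated time of 24 h; a higher number here means that more compound is needed for the effect, a lower number that less compound is needed
compound 2, `Cc1ccccc1C(=O)N(NC(=O)c1ccccc1)C(C)(C)C`, 224 nM in this assay
compound 3, `CCc1ccccc1C(=O)N(NC(=O)c1ccccc1)C(C)(C)C`, 589 nM in this assay

Compound 3 gives the highest number of the three in this assay; the step of a 2.6-fold higher number from compound 2 to compound 3 (0.42 log units; beyond the scatter) and the step of a 3.5-fold higher number from compound 1 to compound 3 (0.54 log units; beyond the scatter) both lie beyond the scatter, whereas a 1.3-fold higher number from compound 1 to compound 2 (0.12 log units; within the scatter) does not.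

Compound 4, `Cc1cc(C)cc(C(=O)N(NC(=O)c2ccccc2)C(C)(C)C)c1`, has not been measured in this assay. It differs from compound 3 by 3,5-dimethylphenyl in place of 2-ethylphenyl on a carbonyl carbon. Going by the values given here, no measured step bears directly on this change: the three steps so far all exchange one group for another on the aromatic ring while keeping its placing, and none rearranges two methyl groups onto a 3,5-dimethylphenyl. The measured steps are modest in size, and compound 3 already stands at the top of the range, so the expectation is a decrease in the number, estimated as a 5.9-fold lower number from compound 3 to compound 4 (0.77 log units; beyond the scatter), with wide uncertainty. Compound 4 is thus expected to give 100 nM in this assay, within an estimated range of 15 nM to 700 nM.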

Compound 4, half-maximal effective concentration: 69.2 nM
The estimate for compound 4 lay 1.4-fold (0.16 log units) above the measured number; the range from low to high includes it.
By their numbers in this assay, from the lowest: compound 4; then compounds 1 and 2 (each within the scatter of the next); then compound 3.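

In this assay, replacing each of the three groups on the carbonyl carbon with 3,5-dimethylphenyl lowers the number every time, from 2-ethylphenyl (an 8.5-fold lower number from compound 3 to compound 4 (0.93 log units; beyond the scatter)), from 2-methylphenyl (a 3.2-fold lower number from compound 2 to compound 4 (0.51 log units; beyond the scatter)) and from 2-bromophenyl (a 2.5-fold lower number from compound 1 to compound 4 (0.39 log units; beyond the scatter)), and each step lies beyond the scatter. Compound 4 therefore falls below the pair formed by compound 1 and compound 2, which lie within the scatter of each other, and it gives the lowest number of the four. Nothing available explains these steps.

The change removes one ring group and brings in two methyl groups in a single step, so the contribution of each cannot be separated. Also open, going by these compounds, is how a chlorine, a methoxy group or an amine in place of those methyl groups would read in this assay.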